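Swapping a chloro for a methanesulfonamido on compound 1

The compounds below may be only part of what the source reports. "The series", "measured", "known", "first", "only" and "open" are said of these compounds alone.

Measured compounds:
- compound 1 `CNc1nc(NCc2ccc(Cl)cc2)cc(-c2ccccn2)n1` gives 3 nM
- compound 2 `CNc1nc(NCC2CCCCC2)cc(-c2ccccn2)n1` gives 10 nM
- compound 3 `Cc1nc(NCc2ccc(Cl)cc2)cc(-c2ccccn2)n1` gives 17 nM

All three numbers come from a functional assay on HEK293 cells for agonist activity at G-protein coupled receptor 39 (Mus musculus), read by inositol phosphate accumulation; a lower number here means that less compound is needed, a higher number that more compound is needed for the effect. On these numbers compound 1 stands lowest: the nearest is compound 2, reached by a 3.3-fold higher number from compound 1 to compound 2 (0.52 log units; beyond the scatter), and the furthest is compound 3, reached by a 5.7-fold higher number from compound 1 to compound 3 (0.75 log units; beyond the scatter).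

Compound 4 `CNc1nc(NCc2ccc(NS(C)(=O)=O)cc2)cc(-c2ccccn2)n1` is not yet measured. It differs from compound 1 in one place: methanesulfonamido in place of chloro on an aromatic carbon. The chloro sits on the six-membered aromatic ring of carbon only, para to a large group, and the methanesulfonamido takes its place there.

For the measured compounds named here, two measured steps touch compound 1. The step from compound 1 to compound 3 changes the methylamino on the shared core and does not bear on the ring in question. The step from compound 1 to compound 2 replaces the whole 4-chlorophenyl with cyclohexyl and brought a modest rise; it shows that losing the chloro-bearing ring costs some potency but not a great deal. Going by the values given here, no measured step exchanges the chloro itself for a larger group. With only this to go on, a modest rise in this assay is expected for compound 4, with wide uncertainty. For compound 4 the estimate is 10 nM, within 2 nM to 60 nM, which would mean a 3.3-fold higher number from compound 1 to compound 4 (0.52 log units; beyond the scatter).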

Compound 4, half-maximal effective concentration: 8 nM
The estimate for compound 4 lay 1.3-fold (0.10 log units) above the measured number; low and high end bracket the measured number.
By their numbers in this assay, from the lowest: compound 1; then compounds 4, 2 and 3 (each within the scatter of the next, the first and the last beyond it).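

The exchange of chloro for methanesulfonamido at this aromatic carbon gives, in this assay, a 2.7-fold higher number from compound 1 to compound 4 (0.43 log units; beyond the scatter), a modest change for a much larger group. For the compounds shown here, until now, the only measured change to this ring replaced the whole 4-chlorophenyl with cyclohexyl, so nothing showed what happens when the ring stays and only the group on it is exchanged; compound 4 shows that this position accepts a group of several more heavy atoms, one that adds a hydrogen-bond donor and hydrogen-bond acceptors where the chloro has neither, at only this modest cost. There is no measurement here that explains why the number moves so little, and the step alone cannot tell which feature of the new group matters.

On these data alone, whether the sulfonyl part or the sulfonamide hydrogen counts more remains open, and a methyl sulfone or an acetamido group on the same carbon would help to separate the two. The compounds shown also leave open how a carboxylic acid or a primary amine would fare here, and whether the same exchange would give a similar step on compound 3.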